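Working notes: aryl swap from compound 2 to compound 3

A few compounds are considered here, and "the series" means these few. Any claim that something is new, unique, unknown or untested is made for them only; others in the source may bear on it.

Compound 1 `CCCc1ccc(NC(=O)C2CCN(C/C=C/c3ccccc3)CC2)cc1`: 9470 nM
Compound 2 `COc1ccccc1NC(=O)C1CCN(C/C=C/c2ccccc2)CC1`: > 100000 nM (a limit, not a number)

All values come from a functional assay on A549 cells (Homo sapiens) for inhibition, read by MTT assay, with a stated time of 72 h; on this read-out lower numbers stand for stronger inhibition and higher numbers for weaker inhibition. For compound 2 the assay gives only a limit, > 100000 nM. Its place in the series is the limit of > 100000 nM in this assay, at which 1 of the 2 values shown sits.

Compound 3 `O=C(Nc1cccc(F)c1)C1CCN(C/C=C/c2ccccc2)CC1` is not yet measured. The change is 3-fluorophenyl in place of 2-methoxyphenyl on an amide-type nitrogen, with 3-fluorophenyl in place of 2-methoxyphenyl on an amide-type nitrogen.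

For the measured compounds named here, one measured step bears on this position: an at least 10-fold higher number from compound 1 to compound 2 (1.02 log units; beyond the scatter). It is large and beyond the scatter, and it is the step that brought in the 2-methoxyphenyl group. Compound 3 gives that group up again, so a clear step towards lower numbers is expected in this assay, though probably a moderate one. Going by the values given here, no measured compound carries 3-fluorophenyl, so the size remains uncertain. The closest measured reference is compound 1 with 9470 nM, and a result near that level would be the favourable end. The expected step is an at least 2.8-fold lower number from compound 2 to compound 3 (0.45 log units; beyond the scatter). For compound 3 the estimate is 35000 nM, with an expected range of 10000 nM to 100000 nM.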

Compound 3, half-maximal inhibitory concentration: 43300 nM
Beside the measured number, compound 3's estimate is 1.2-fold (0.09 log units) below it, and the stated range covers the measured number.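

In this assay, the position on the amide-type nitrogen still gives a readable value without the 4-propylphenyl group, so the loss seen with 2-methoxyphenyl does not extend to every replacement of that group: the change to 3-fluorophenyl appears as an at least 2.3-fold lower number from compound 2 to compound 3 (0.36 log units; beyond the scatter). Compound 2 holds only a limit, not a number: the limit of > 100000 nM in this assay, at which 1 of the 3 values shown sits. Measured against the 4-propylphenyl group, however, 3-fluorophenyl does not match it, with a 4.6-fold higher number from compound 1 to compound 3 (0.66 log units; beyond the scatter), which places the three aryl groups in a clear order at this position, with 4-propylphenyl giving the lowest number, 3-fluorophenyl next and 2-methoxyphenyl last.

The three aryl groups differ from one another both in the substituent and in where it sits on the ring, so the compounds shown cannot tell whether the lower number of compound 1 goes with the propyl chain itself or with its place, a question that 4-fluorophenyl or 4-methoxyphenyl on the same amide-type nitrogen would bear on. Going by these compounds, whether a longer chain, such as that of 4-butylphenyl, lowers the number further also remains open.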